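A Second Methoxy Group on the Free-Amine Core

This account rests on a few compounds, and the source may have more. Where it says the series, first, only, none or still open, it means among the compounds named here.

Measured so far in an ADME assay on CCRF-CEM cells (Homo sapiens) for antiproliferative activity, with a stated time of 48 h; a lower number here means a stronger inhibitor, a higher number a weaker inhibitor:
compound 1, `C=C(Br)C(=O)Nc1ccc(C(=O)/C=C/c2cccc(OC)c2)cc1`, gives 1800 nM
compound 2, `C=C(Br)C(=O)Nc1ccc(C(=O)/C=C/c2ccc(OC)c(OC)c2)cc1`, gives 1600 nM
compound 3, `COc1cccc(/C=C/C(=O)c2ccc(N)cc2)c1`, gives 23000 nM

Compound 4, `COc1cc(/C=C/C(=O)c2ccc(N)cc2)cc(OC)c1`, has not yet been measured in this assay.

Two changes link these compounds. From compound 1 to compound 2 the change is methoxy in place of hydrogen on an aromatic carbon, and the step is a 1.1-fold lower number from compound 1 to compound 2 (0.05 log units; within the scatter). From compound 1 to compound 3 the cores part ways: hydrogen in place of (1-bromoethenyl)carbonyl on a nitrogen on an aromatic ring, with the step of a 13-fold higher number from compound 1 to compound 3 (1.11 log units; beyond the scatter). The change from compound 3 to compound 4 is methoxy in place of hydrogen on an aromatic carbon. It is the same kind of change as from compound 1 to compound 2, but not the same: in compound 2 the entering methoxy sits ortho to a methoxy group and para to a large group, whereas in compound 4 it sits meta to a large group and meta to a methoxy group. Seen once among these compounds, this kind of change gave a step within the scatter, so a similarly small step is expected here, a 1.2-fold lower number from compound 3 to compound 4 (0.06 log units; within the scatter), resting on a 1.1-fold lower number from compound 1 to compound 2 (0.05 log units; within the scatter). Compound 4 is therefore estimated at 20000 nM, between 8000 nM and 50000 nM.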

Compound 4, half-maximal inhibitory concentration: 5700 nM
Compound 4: middle estimate off by 3.5-fold (0.55 log units), on the high side; the measured number lies below the stated range.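

In this assay, putting a methoxy group in place of hydrogen on the free-amine core gives a 4.0-fold lower number from compound 3 to compound 4 (0.61 log units; beyond the scatter) and so makes a real difference to the number. On the core of compound 1, the same kind of change did not, and the two results do not agree: the same change on two cores in this assay, a 1.1-fold lower number (0.05 log units; within the scatter) from compound 1 to compound 2 and a 4.0-fold lower number (0.61 log units; beyond the scatter) from compound 3 to compound 4, 3.6-fold (0.55 log units) apart, beyond the scatter of two such steps. This shows that the size of the step seen on one core could not be carried over to the other, but it does not show why, since the entering methoxy also sits in a different place in compound 2 than in compound 4, and so the core and the position cannot be told apart with only these two pairs.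

The compounds shown leave open whether the methoxy arrangement of compound 4 would give a similar step on the core that carries the (1-bromoethenyl)carbonyl group. They also leave open whether a hydroxy or an ethoxy group in that place would behave as methoxy does.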